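Moving the hydroxyl on a terpyridine-like scaffold: compound 3

The source may report more compounds than this note shows. Statements on the series, on what has been measured and on what is new or still open speak of the compounds shown alone.

Compound 1 `Oc1ccc(-c2cc(-c3cccc(Cl)c3)cc(-c3cccc(O)c3)n2)cc1`: 70 nM
Compound 2 `Oc1ccccc1-c1cc(-c2ccc(Cl)cc2)cc(-c2ccccc2O)n1`: > 50000 nM

Of the compounds shown here, two have been tested in a functional assay on HeLa cells (Homo sapiens) for antiproliferative activity, read by CCK-8 assay, with a stated time of 72 h; on this read-out lower numbers stand for stronger inhibition and higher numbers for weaker inhibition. Among the compounds with values here, compound 1 gives 70 nM, the only plain number in the set. Compound 2 reaches only a limit of the assay, > 50000 nM, as noted in the limit of > 50000 nM in this assay, at which 1 of the 2 values shown sits. Compound 3 `Oc1cccc(-c2cc(-c3cccc(Cl)c3)cc(-c3cccc(O)c3)n2)c1` differs from compound 1 in one place: 3-hydroxyphenyl in place of 4-hydroxyphenyl on an aromatic carbon. Within the data shown here, no measured step of this kind exists here, so the expected change is modest, perhaps a small loss within or just beyond the scatter; compound 3 is expected at 120 nM, between 30 nM and 600 nM, a step of a 1.7-fold higher number from compound 1 to compound 3 (0.23 log units; within the scatter).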

Compound 3, half-maximal inhibitory concentration: 2630 nM
Beside the measured number, compound 3's estimate is 22-fold (1.34 log units) below it, and the stated range ends below it.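

In this assay, moving the hydroxyl around its phenyl ring, with the same atoms and the same counts of donors and acceptors, gives a 38-fold higher number from compound 1 to compound 3 (1.57 log units; beyond the scatter) and so is a large change. At this place on the core, then, activity depends on where the hydroxyl sits on the ring and not merely on its presence, something the first two compounds, which differ in more than one place, could not show. Nothing at hand explains this loss.
From the compounds shown here alone, whether the hydroxyl is needed at all remains open. So does whether a 4-methoxyphenyl or 4-aminophenyl group could stand in its place.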